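The source may hold more compounds than are shown below. What is called first, only, known or untested is meant among the compounds shown, and "the series" means these compounds.

Compound 1, `O=C(/C=C\Nc1cnc2ccccc2c1)c1nc(-c2ccc(C(F)(F)F)cc2)n2ccccc12`; compound 2, `O=C(/C=C\Nc1ccc2[nH]ccc2c1)c1nc(-c2ccc(C(F)(F)F)cc2)n2ccccc12`.

In a functional assay on MDA-MB-231 cells (Homo sapiens) for cytotoxicity, read by MTT assay, with a stated time of 48 h (a lower number here means a stronger inhibitor, a higher number a weaker inhibitor), compound 1 gives > 30000 nM, which is a limit of the assay rather than a number. In this assay compound 2 gives 1180 nM, the only number shown, so compound 2 stands alone as the sole measured point, with compound 1 sitting at the limit of > 30000 nM in this assay, at which 1 of the 2 values shown sits. Going by the values given here, the single measured step, an at least 25-fold lower number from compound 1 to compound 2 (1.40 log units; beyond the scatter), shows that the group on the amine nitrogen can move the value strongly.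

Compound 3, `COc1ccc(N/C=C\C(=O)c2nc(-c3ccc(C(F)(F)F)cc3)n3ccccc23)cc1`, differs from compound 2 by 4-methoxyphenyl in place of 1H-indol-5-yl on an amine nitrogen. Among the compounds with values here, no measured step covers this exchange directly; the step from compound 1 to compound 2 only indicates that this position is sensitive. Compound 3 is therefore expected to give a step of a 3.4-fold higher number from compound 2 to compound 3 (0.53 log units; beyond the scatter) toward a weaker value, and its result in this assay is estimated at 4000 nM, within 800 nM to 30000 nM.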

Compound 3, half-maximal inhibitory concentration: > 30000 nM
Compound 3 gave a limit, no number (the forecaster's own chance of this, stated with the estimate: 25%); at least 7.5-fold (0.87 log units) between middle value and limit.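

In this assay, the change from 1H-indol-5-yl to 4-methoxyphenyl on the amine nitrogen gives an at least 25-fold higher number from compound 2 to compound 3 (1.40 log units; beyond the scatter), so the sensitivity of this position now shows in a second exchange, with a different incoming group. This exchange takes away the hydrogen-bond donor of 1H-indol-5-yl and brings in a hydrogen-bond acceptor, though two compounds cannot tell whether either count matters. Compound 1 and compound 3 both carry limits, so the step between them cannot be read, and compound 2 remains the only one with a number: the limit of > 30000 nM in this assay, at which 2 of the 3 values shown sit.

As far as these compounds go, whether the ring hydrogen of the indole is what separates compound 2 from the others stays open. So does the result of placing 1-methyl-1H-indol-5-yl, 4-hydroxyphenyl or unsubstituted phenyl on the same nitrogen.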